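A Small Aromatic Swap in a Series Without Measurable Activity

The compounds below may be only part of what the source reports. "The series", "measured", "known", "first", "only" and "open" are said of these compounds alone.

Compound 1 `CCOC(=O)C1=Cc2ccccc2OC1(OCc1cn(-c2cccc(OC)c2)nn1)C(F)(F)F` was tested in a functional assay on MCF7 cells (Homo sapiens) for inhibition, read by MTT assay, with a stated time of 24 h; on this read-out lower numbers stand for stronger inhibition and higher numbers for weaker inhibition. In this assay compound 1 gives > 150000 nM, which is a limit of the assay rather than a number. Compound 2 `O=C(O)C1=Cc2ccccc2OC1(OCc1cc(-c2ccc3ccccc3c2)no1)C(F)(F)F` shares the same core but carries a different side group. In this assay compound 2 gives > 150000 nM, again a limit and not a measured number. Among the measured compounds shown here, compound 1 therefore stands at the edge of what this assay can see, and the only other value shown sits at that same edge (the limit of > 150000 nM in this assay, at which 2 of the 2 values shown sit).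

Compound 3 `CCOC(=O)C1=Cc2ccccc2OC1(OCc1cn(-c2ccc(C)cc2)nn1)C(F)(F)F` has not been measured yet. It differs from compound 1 in one place: 4-methylphenyl in place of 3-methoxyphenyl on an aromatic nitrogen. No step between measured compounds is shown, so there is no measured change of a similar kind to lean on. Because both measured values sit at the limit (the limit of > 150000 nM in this assay, at which 2 of the 2 values shown sit), the step from compound 1 to compound 3 is expected to be none beyond the scatter, a step that the limit leaves unreadable from compound 1 to compound 3. Compound 3 is thus expected to give about 200000 nM in this assay, within a range from 100000 nM to 500000 nM, and most likely to be reported as a limit once more.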

Compound 3, half-maximal inhibitory concentration: 26700 nM
For compound 3 the middle estimate is 7.5-fold (0.87 log units) above the measured one; measured number outside the range, below it.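

Among the compounds shown here, the group on the aromatic nitrogen does affect the result in this assay: the swap to 4-methylphenyl gives an at least 5.6-fold lower number from compound 1 to compound 3 (0.74 log units; beyond the scatter), a change that could not be seen while the only values shown were limits. This figure gives only the smallest size the step can have, and the true step may be larger, because compound 1 has a limit rather than a measured number: the limit of > 150000 nM in this assay, at which 2 of the 3 values shown sit. The swap also changes more than one feature at once, since the substituent on the phenyl ring differs, its printed ring number differs, and the hydrogen-bond acceptor counted in 3-methoxyphenyl is gone in 4-methylphenyl, so this single step cannot show which feature accounts for the lower number.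

The compounds shown leave open whether the lower number follows the methyl group or its place on the phenyl ring, a question that 3-methylphenyl and 4-methoxyphenyl on the same nitrogen could help to separate. They also leave open how an unsubstituted phenyl or a larger 4-ethylphenyl at this position would compare with compound 3.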